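Taking the bromo group off compound 3

The compounds below may be only part of what the source reports. "The series", "measured", "known", "first", "only" and "open" are said of these compounds alone.

In a physicochemical assay for lipophilicity (a lower number here means a more polar compound, a higher number a more lipophilic compound), compound 3 `C[C@H]1CC[C@@H]2[C@@H](OC(=O)[C@]23CC(c2ccccc2Br)=NO3)[C@]2(C)C(=O)C=C[C@@]12O` reads 2.22 and sits in the middle of the three measured compounds. Compound 1 `C[C@H]1CC[C@@H]2[C@@H](OC(=O)[C@]23CC(c2c(Cl)cccc2Cl)=NO3)[C@]2(C)C(=O)C=C[C@@]12O` gives 2.67 as the highest, and compound 2 `COc1ccc(C2=NO[C@]3(C2)C(=O)O[C@@H]2[C@H]3CC[C@H](C)[C@]3(O)C=CC(=O)[C@@]23C)cc1` gives 1.47 as the lowest. Compound 4 `C[C@H]1CC[C@@H]2[C@@H](OC(=O)[C@]23CC(c2ccccc2)=NO3)[C@]2(C)C(=O)C=C[C@@]12O` is not yet measured: it carries hydrogen in place of bromo on an aromatic carbon on the same shared core. For the measured compounds named here, no measured step removes a halogen outright. Both modest, a number 0.45 log units lower from compound 1 to compound 3 (beyond the scatter) and a number 0.75 log units higher from compound 2 to compound 3 (beyond the scatter) are the nearest guides. A modest fall in this assay is therefore expected, with a number 0.47 log units lower from compound 3 to compound 4 (beyond the scatter) as the estimated step. Compound 4 is expected at 1.75 with 1.4 and 2.1 as the ends of its range.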

Compound 4, partition coefficient: 1.41
Compound 4: middle estimate off by 0.34 log units, on the high side; the range from low to high includes it.
By their numbers in this assay, from the lowest: compounds 4 and 2 (each within the scatter of the next); then compound 3; then compound 1.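

Taking the bromo group off outright gives a number 0.81 log units lower from compound 3 to compound 4 (beyond the scatter) in this assay, so this single halogen carries a measurable share of the reading. Removing both chloro groups gives a number 1.26 log units lower from compound 1 to compound 4 (beyond the scatter), so both halogen-bearing compounds read above the unsubstituted phenyl compound. Compound 2 goes against any wider trend among substituents: the change to hydrogen gives a number 0.06 log units lower from compound 2 to compound 4 (within the scatter), so the methoxy group cannot be told from hydrogen here.

Where an amine or a carboxylic acid on this ring would fall relative to compound 4 remains open. No measurement shown explains why these steps differ in size.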